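Extending the Benzylamine Arm of a Diaryl Ether Series

The compounds below may be only part of what the source reports. "The series", "measured", "known", "first", "only" and "open" are said of these compounds alone.

Measured compounds:
Compound 1 `COc1cc(Oc2cccc(Nc3ccccc3)c2)cc(OC)c1CNCc1ccccc1` — 3340 nM
Compound 2 `COc1cc(Oc2cccc(Nc3ccccc3)c2)cc(OC)c1CNCc1ccc(Cl)cc1` — 3350 nM

Compound 2 stands at the higher of the two numbers measured in a functional assay on HT-29 cells (Homo sapiens) for inhibition, read by MTT assay, with a stated time of 72 h (on this read-out lower numbers stand for stronger inhibition and higher numbers for weaker inhibition), with compound 1 as its nearest neighbour, a difference that lies within the scatter: a 1.0-fold higher number from compound 1 to compound 2 (0.00 log units; within the scatter). On these two numbers, therefore, no order between compound 1 and compound 2 can be claimed.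

Compound 3 `COc1ccc(CCCNCc2c(OC)cc(Oc3cccc(Nc4ccccc4)c3)cc2OC)cc1` has not yet been measured in this assay. It differs from compound 2 in one place: 2-(4-methoxyphenyl)ethyl in place of 4-chlorophenyl on a saturated chain carbon bound to an amine nitrogen. Viewed one bond further out, the 4-chlorobenzyl group gives way to a 3-(4-methoxyphenyl)propyl group on the amine nitrogen.

Among the compounds with values here, the only measured step, from compound 1 to compound 2, exchanged a ring hydrogen for chlorine on the same arm and did nothing beyond the scatter. That step bears on the present change only loosely, since the arm is now lengthened and its ring substituent changed at once. Within the data shown here, with no measured step of this kind, the expected step is set at about none beyond the scatter, a 1.1-fold lower number from compound 2 to compound 3 (0.05 log units; within the scatter), with a wide allowance either way.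

Compound 3 is accordingly estimated at 3000 nM, within a range of 1100 nM to 8500 nM.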

Compound 3, half-maximal inhibitory concentration: 3320 nM
Compound 3: middle estimate off by 1.1-fold (0.04 log units), on the low side; the range from low to high includes it.
By their numbers in this assay, from the lowest: compounds 3, 1 and 2 (each within the scatter of the next).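

In this assay, the 3-(4-methoxyphenyl)propyl arm on the amine nitrogen stands level with the 4-chlorobenzyl arm (a 1.0-fold lower number from compound 2 to compound 3 (0.00 log units; within the scatter)) and with the plain benzyl arm (a 1.0-fold lower number from compound 1 to compound 3 (0.00 log units; within the scatter)). Within the data shown here, the earlier pair had tested only a ring hydrogen against chlorine, whereas this change brings a longer chain, a larger group of 10 heavy atoms in place of 7, and a methoxy oxygen counted as a hydrogen-bond acceptor, and still no step among the three compounds goes beyond the scatter. Nothing available accounts for this flatness, so it stands as an observation without an explanation.

The compounds shown leave open whether any arm at this amine nitrogen would give a step beyond the scatter, for instance one ending in a carboxylic acid, a morpholine or a pyridine, or a chain of the same length with no ring at its end. They also leave open whether an amide in place of the amine, or a change in the shared core away from this arm, would move the number in this cell assay.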